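Removing a methyl from compound 2: an expected small shift

The source may report more compounds than this note shows. Statements on the series, on what has been measured and on what is new or still open speak of the compounds shown alone.

Of the compounds shown here, two have been measured in a functional assay on HepG2 cells (Homo sapiens) for antiproliferative activity, read by MTT assay, with a stated time of 48 h; on this read-out higher numbers stand for weaker inhibition and lower numbers for stronger inhibition. Compound 1, `O=c1cc(-c2ccccc2)oc2cc(O)c(OCCCN3CCCCC3)c(O)c12`, gives 70600 nM in this assay. Compound 2, `COc1cc2oc(-c3ccccc3)cc(=O)c2c(O)c1OCCCCN1CCN(C)CC1`, gives 36700 nM in this assay, the lower of the two numbers shown, though the gap to compound 1 lies within the usual scatter of the measurement, so the two cannot be ranked against each other on this evidence.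

Compound 3, `CN1CCN(CCCCOc2c(O)cc3oc(-c4ccccc4)cc(=O)c3c2O)CC1`, has not yet been measured. It differs from compound 2 in one place: hydrogen in place of methyl on an oxygen on an aromatic ring, which cut one bond further out reads methoxy to hydroxy. For the measured compounds named here, no step between two measured compounds covers this change, so the account rests on the two numbers above and the small size of the change.

Compound 3 is expected to give about 45000 nM in this assay, within a range of 15000 nM to 120000 nM. The step this estimate implies, a 1.2-fold higher number from compound 2 to compound 3 (0.09 log units; within the scatter), is expected to stay within the scatter, with no clear direction.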

Compound 3, half-maximal inhibitory concentration: 93700 nM
Compound 3: the middle estimate sits 2.1-fold (0.32 log units) below what was measured; measured number inside the range.
By their numbers in this assay, from the lowest: compounds 2, 1 and 3 (each within the scatter of the next, the first and the last beyond it).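

In this assay, for the compounds shown here, methoxy to hydroxy on the aromatic ring is the first change whose size can be read, and hydrogen in place of methyl on that oxygen gives a 2.6-fold higher number from compound 2 to compound 3 (0.41 log units; beyond the scatter) as a modest step, beyond the scatter and towards weaker inhibition. This position therefore does respond to the change, although the effect is small and rests on a single pair. The other step, (4-methylpiperazin-1-yl)methyl in place of piperidin-1-yl on a saturated chain carbon, three bonds along the chain from an oxygen on an aromatic ring, gives a 1.3-fold higher number from compound 1 to compound 3 (0.12 log units; within the scatter) and stays within the scatter, so this pair shows no readable difference, and no measured evidence accounts for either step.

On these data alone, whether other groups on this oxygen, such as ethoxy or an acetyl ester, would follow methoxy or hydroxy remains open. Also open, as far as these compounds go, is how the numbers would respond with the shared core kept and a shorter chain or a morpholine placed at the chain end.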